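A few compounds are considered here, and "the series" means these few. Any claim that something is new, unique, unknown or untested is made for them only; others in the source may bear on it.

Compound 1 `COc1cc(C2=C(c3cc(C)c(OC)c(C)c3)C(O)CC2=O)cc(OC)c1OC`: > 100 ug/mL
Compound 2 `COc1cc(C2=C(c3cc(C)c(OC)c(C)c3)C(OC(C)=O)CC2=O)cc(OC)c1OC`: > 100 ug/mL
Compound 3 `CC(=O)OC1C/C(=N/O)C(c2ccccc2)=C1c1ccccc1`: > 100 ug/mL

Of the compounds shown here, three have been tested in an ADME assay on L132 cells (Homo sapiens) for cytotoxicity, read by MTT assay, with a stated time of 72 h; a lower number here means a stronger inhibitor, a higher number a weaker inhibitor. Compound 1 gives > 100 ug/mL, which is a limit of the assay and not a number. Compound 2 gives > 100 ug/mL, again only a limit. Compound 3 gives > 100 ug/mL, also a limit. All three values sit at the limit of > 100 ug/mL in this assay, at which 3 of the 3 values shown sit.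

Compound 2 and compound 1 differ in one place: hydrogen in place of acetyl on an oxygen on a saturated carbon The step that the two limits leave unreadable from compound 2 to compound 1 cannot be read, since both values are limits. Compound 3 has a core unlike that of compound 2; the difference between the two cores is not broken down here.

Compound 4 `O/N=C1/CC(O)C(c2ccccc2)=C1c1ccccc1` has not yet been measured in this assay. It differs from compound 3 by the same change that separates compound 2 and compound 1: hydrogen in place of acetyl on an oxygen on a saturated carbon Because compound 3 gives > 100 ug/mL and the earlier step that the two limits leave unreadable from compound 2 to compound 1 gave no readable size, compound 4 is expected to stay at the limit too, with an expected step that the limit leaves unreadable from compound 3 to compound 4. Compound 4 is estimated at 150 ug/mL, between 80 ug/mL and 400 ug/mL.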

Compound 4, half-maximal inhibitory concentration: > 100 ug/mL
Compound 4 gave a limit, no number (the forecaster's own chance of this, stated with the estimate: 85%); the middle value does not contradict the limit.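

Compound 3 and compound 4 both stand at a limit of the assay and not at a number, so no step from acetoxy to hydroxy can be read between them: the limit of > 100 ug/mL in this assay, at which 4 of the 4 values shown sit.

The compounds shown leave open what number any of the four would give in this assay and whether this change alters that number at all.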